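Carboxy in place of the boron group: compound 1 to compound 3

This account rests on a few compounds, and the source may have more. Where it says the series, first, only, none or still open, it means among the compounds named here.

Compound 1 `COc1cc2ncnc(Nc3ccc(B(O)O)cc3)c2cc1OC` gives 49% in an assay on isolated protein for inhibition of vascular endothelial growth factor receptor 1 (Homo sapiens), read by ELISA, with a stated time of 20 min, tested at 1 uM; on this read-out higher numbers stand for more inhibition at the one concentration tested (going by the name of the read-out) and lower numbers for less inhibition. For the measured compounds named here, it is the only member of the set with a number; compound 2 `COc1cc2ncnc(Nc3cccc(Cl)c3)c2cc1B1OC(C)(C)C(C)(C)O1` was reported in this assay as "not active" (no number reported), with no figure attached. Compound 3 `COc1cc2ncnc(Nc3ccc(C(=O)O)cc3)c2cc1OC` differs from compound 1 by a group of 3 heavy atoms (1 carbon, 2 oxygen; no ring) in place of a group of 3 heavy atoms (1 boron, 2 oxygen; no ring), on an aromatic carbon. Going by the values given here, no step between two measured compounds exists to calibrate this change. A small loss, within or just beyond the scatter, is expected for a number 9 percentage points lower from compound 1 to compound 3 (within the scatter). Compound 3 is accordingly estimated at about 40%, most likely between 15% and 62%.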

Compound 3, a percentage reported as inhibition, at one concentration (the size of the read-out at that concentration, not a potency): "not active" (no number reported)
Compound 3: no number reported, and the estimate cannot be compared.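

In this assay no step can be read from compound 1 to compound 3, as compound 3 is reported without a number. The compounds shown leave open the size of the change on placing carboxy in the boron group's position. No available evidence bears on this result.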